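This account rests on a few compounds, and the source may have more. Where it says the series, first, only, none or still open, it means among the compounds named here.

In a functional assay on HCT-116 cells (Homo sapiens) for antiproliferative activity, read by MTT assay, with a stated time of 72 h (on this read-out higher numbers stand for weaker inhibition and lower numbers for stronger inhibition), compound 2 (`COc1cc(CCc2ccc(Cl)cc2)cc(OC)c1O`) gives 330 nM, within the scatter of compound 1 (`COc1cc(CCc2ccccc2Cl)cc(OC)c1O`) at 250 nM, while compound 3 (`COc1cc(CCc2ccc([N+](=O)[O-])cc2)cc(OC)c1O`) gives a clearly higher number, 3160 nM.

The next structure, compound 4 (`COc1cc(CCc2ccc(Cl)cc2Cl)cc(OC)c1O`), keeps the chloro group of compound 2 and adds a second one, chloro in place of hydrogen on an aromatic carbon.

For the measured compounds named here, the only measured single-place step is a 9.6-fold higher number from compound 2 to compound 3 (0.98 log units; beyond the scatter), a modest move beyond the scatter. It swaps nitro for chloro at another place, so it gives no direct size for this addition. Going by the values given here, no measured step adds a chloro group to a compound. Compound 4 carries chloro at both of the places used singly in compound 1 and compound 2. Compound 1 at 250 nM and compound 2 at 330 nM lie within the scatter of each other.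

No move beyond the scatter is therefore expected, with a slight lean towards a lower number. The expected step is a 1.3-fold lower number from compound 2 to compound 4 (0.12 log units; within the scatter). For compound 4 the estimated value is 250 nM, with an expected range of 100 nM to 620 nM.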

Compound 4, half-maximal inhibitory concentration: 2980 nM
Estimate against measurement, compound 4: 12-fold (1.08 log units) below; the measured number lies above the stated range.
By their numbers in this assay, from the lowest: compounds 1 and 2 (each within the scatter of the next); then compounds 4 and 3 (each within the scatter of the next).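

In this assay a single chloro group gives similar numbers at either of the two places, but chloro at both does not. Adding chloro ortho to a large group and meta to a chloro group gives a 9.0-fold higher number from compound 2 to compound 4 (0.96 log units; beyond the scatter) and adding the second chloro group to the other single-chloro compound gives a 12-fold higher number from compound 1 to compound 4 (1.08 log units; beyond the scatter) so the two single placements give no guide to the pair, which compound 1 and compound 2 alone could not show. Nothing at hand accounts for this rise.

Going by these compounds, whether the rise needs chloro at both places, or would also follow another second group, stays open. A methyl group or an amine ortho to a large group on compound 2 would show whether this place itself or the pairing of two chloro groups sets the number.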